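Chain extension from compound 2 to compound 3

The source may hold more compounds than are shown below. What is called first, only, known or untested is meant among the compounds shown, and "the series" means these compounds.

Compound 1 (`CCCCCCCC(CCO)n1cnc2c(Cl)ncnc21`) gives 4160 nM
Compound 2 (`CCCCCCCC(CCO)n1cnc2c(N(C)C)ncnc21`) gives > 50000 nM
Compound 3 (`CCCCCCCCCCC(CCO)n1cnc2c(N(C)C)ncnc21`) is not yet measured

All values come from a functional assay on HCT-116 cells (Homo sapiens) for antiproliferative activity, read by MTT assay, with a stated time of 48 h; a higher number here means a weaker inhibitor, a lower number a stronger inhibitor. For compound 2 the entry > 50000 nM is a limit of the assay and not a number. The change to compound 3 is propyl in place of hydrogen on a saturated chain carbon, eight bonds along the chain from an aromatic nitrogen. Within the data shown here, the only measured step, an at least 12-fold higher number from compound 1 to compound 2 (1.07 log units; beyond the scatter), was large but lay on an aromatic carbon, not on the chain, so it bears only indirectly. Among the measured compounds shown here, no measured step covers the chain, so a modest move toward a lower number is expected, and the result may remain a limit. The expected step is an at least 1.6-fold lower number from compound 2 to compound 3 (0.22 log units; that floor lies within the scatter). The estimate for compound 3 is 30000 nM, with an expected range from 10000 nM to 60000 nM.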

Compound 3, half-maximal inhibitory concentration: 5490 nM
The estimate for compound 3 lay 5.5-fold (0.74 log units) above the measured number; measured number below the stated range.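

The chain is a place where the read-out responds: propyl in place of hydrogen on a saturated chain carbon, eight bonds along the chain from an aromatic nitrogen, gives an at least 9.1-fold lower number from compound 2 to compound 3 (0.95 log units; beyond the scatter). With dimethylamino kept on the aromatic carbon, the chain change alone turns a limit into a measured number. The size of this step remains a floor: the limit of > 50000 nM in this assay, at which 1 of the 3 values shown sits.

Going by these compounds, whether a still longer chain lowers the number further remains open. So does whether chloro, or an amine such as methylamino, on the aromatic carbon would behave the same way with this longer chain.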